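Adding a Third Methoxy Group to a Benzimidazole Biphenyl Scaffold

The compounds below may be only part of what the source reports. "The series", "measured", "known", "first", "only" and "open" are said of these compounds alone.

Measured compounds:
compound 1, `c1ccc(-c2ccc(-c3ccc(-c4nc5ccccc5[nH]4)cc3)cc2)cc1`, 41200 nM
compound 2, `COc1ccc(-c2ccc(-c3ccc(-c4nc5ccccc5[nH]4)cc3)cc2)cc1`, 100000 nM
compound 3, `COc1ccc(-c2ccc(-c3ccc(-c4nc5c(O)cccc5[nH]4)cc3)cc2)cc1OC`, 1240 nM

Of the compounds shown here, three have been measured in a functional assay on PC-3 cells (Homo sapiens) for inhibition, read by sulforhodamine B assay; on this read-out lower numbers stand for stronger inhibition of growth and higher numbers for weaker inhibition of growth. Compound 1 gives 41200 nM, and compound 2 gives 100000 nM; the change between them, (methoxy in place of hydrogen on an aromatic carbon), produced a 2.4-fold higher number from compound 1 to compound 2 (0.39 log units; beyond the scatter). Compound 3 gives 1240 nM, the lowest of the three numbers; how its core differs from the core of compound 1 is not broken down here, and its separation from both other compounds lies beyond the scatter.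

Compound 4, `COc1cc(-c2ccc(-c3ccc(-c4nc5c(O)cccc5[nH]4)cc3)cc2)cc(OC)c1OC`, has not yet been measured. It differs from compound 3 by methoxy in place of hydrogen on an aromatic carbon. Among the measured compounds shown here, this is the same kind of change as the one from compound 1 to compound 2, but it does not sit at the same kind of place: in compound 2 the methoxy entered para to a large group, whereas in compound 4 it enters ortho to a methoxy group, meta to a large group and meta to a methoxy group.

Given that the only measured methoxy addition gave a 2.4-fold higher number from compound 1 to compound 2 (0.39 log units; beyond the scatter), the step from compound 3 to compound 4 in this assay is expected to be of similar, modest size, a 2.0-fold higher number from compound 3 to compound 4 (0.30 log units; within the scatter), though the different surroundings leave room for a different outcome. Compound 4 is therefore estimated at 2500 nM, with a plausible range from 800 nM to 8000 nM.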

Compound 4, concentration for 50% growth inhibition: 170 nM
Estimate against measurement, compound 4: 15-fold (1.17 log units) above; the measured number lies below the stated range.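

In this assay, methoxy in place of hydrogen on an aromatic carbon gave a 7.3-fold lower number from compound 3 to compound 4 (0.86 log units; beyond the scatter), the opposite direction to the earlier step (a 2.4-fold higher number from compound 1 to compound 2 (0.39 log units; beyond the scatter)) , so compound 4 inhibits growth more strongly than compound 3 in this series. The change therefore does not carry from one core to another with a fixed size or even a fixed sign: the same change on two cores in this assay, a 2.4-fold higher number (0.39 log units; beyond the scatter) from compound 1 to compound 2 and a 7.3-fold lower number (0.86 log units; beyond the scatter) from compound 3 to compound 4, 18-fold (1.25 log units) apart, beyond the scatter of two such steps. What this does not show is the source of the reversal, since the core of compound 3 differs from the core of compound 1, the new methoxy in compound 4 sits ortho to a methoxy group, and two steps cannot separate the contribution of the core from that of the place.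

The compounds shown leave open whether a methoxy is needed at this place in compound 4, or whether an ethoxy group or a fluorine there would give a similar number. They also leave open what the three methoxy groups of compound 4 would do on the core of compound 1, and whether an amine in place of the hydroxyl group of compound 3 would hold the number.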